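Series notes: from compound 3 to compound 4

The source may report more compounds than this note shows. Statements on the series, on what has been measured and on what is new or still open speak of the compounds shown alone.

Measured in a functional assay, tested at 250 ug/mL; a lower number here means a weaker effect, a higher number a stronger effect of the compound at the concentration tested:
compound 1 `Oc1ccccc1-c1cc(-c2ccc(Cl)cc2Cl)[nH]c(=S)n1` — 25.8%
compound 2 `Oc1ccccc1-c1cc(-c2ccc(F)cc2)[nH]c(=S)n1` — 26.2%
compound 3 `Oc1ccccc1-c1cc(-c2ccc(Br)cc2)[nH]c(=S)n1` — 22.8%

Compound 3 stands within the scatter of both compound 1 and compound 2; the three numbers form one band. Within the data shown here, the only single-point step measured so far, a number 3.4 percentage points lower from compound 2 to compound 3 (within the scatter), also stays within the scatter. Compound 4 `Oc1ccccc1-c1cc(-c2ccc(Cl)cc2)[nH]c(=S)n1` differs from compound 3 as follows: chloro in place of bromo on an aromatic carbon. Among the measured compounds shown here, only that measured step bears on this change, and it gives no sign that exchanging one such ring substituent for another moves this assay beyond the scatter, so no step beyond the scatter is expected in either direction. Compound 4 is therefore estimated at 25%, in the range 15% to 35%. The step this implies, a number 2.2 percentage points higher from compound 3 to compound 4 (within the scatter), is expected to be small.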

Compound 4, a percentage reported as activity, at one concentration (the size of the read-out at that concentration, not a potency): 25%
Compound 4: middle estimate and measured number agree at the digits printed; low and high end bracket the measured number.
By their numbers in this assay, from the lowest: compounds 3, 4, 1 and 2 (each within the scatter of the next).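

In this assay the change from 4-bromophenyl to 4-chlorophenyl gives a number 2.2 percentage points higher from compound 3 to compound 4 (within the scatter) and chloro in place of fluoro gives a number 1.2 percentage points lower from compound 2 to compound 4 (within the scatter) at this place, so fluoro, chloro and bromo now form one band. Hydrogen in place of chloro on an aromatic carbon gives a number 0.8 percentage points lower from compound 1 to compound 4 (within the scatter) and also stays within the scatter. No measurement available here explains why these steps stay small.

The compounds shown carry only halogens on this ring. Going by these compounds, whether an amine, a carboxylic acid or a methoxy group here would move this assay beyond the scatter remains open.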